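Moving from trifluoromethylphenyl back to a fluorophenyl anilino group

This account rests on a few compounds, and the source may have more. Where it says the series, first, only, none or still open, it means among the compounds named here.

For the measured compounds named here, compound 2 `CC(C)c1ccc(-c2nc(SCc3cn(CC(=O)NC(=O)Nc4ccccn4)nn3)nc(Nc3cccc(C(F)(F)F)c3)c2C#N)cc1` holds the lower of the two numbers measured so far: in a functional assay on MCF7 cells (Homo sapiens) for inhibition, read by MTT assay, with a stated time of 72 h (on this read-out lower numbers stand for stronger inhibition and higher numbers for weaker inhibition), compound 2 gives 8620 nM, while compound 1 `CC(C)c1ccc(-c2nc(SCc3cn(CC(=O)NC(=O)Nc4ccccn4)nn3)nc(Nc3ccccc3Cl)c2C#N)cc1` gives 43700 nM. Going by the values given here, the only measured step, a 5.1-fold lower number from compound 1 to compound 2 (0.70 log units; beyond the scatter), shows that the 3-(trifluoromethyl)phenyl group sits on the better side of this pair. Compound 3 `CC(C)c1ccc(-c2nc(SCc3cn(CC(=O)NC(=O)Nc4ccccn4)nn3)nc(Nc3ccccc3F)c2C#N)cc1` carries the change (2-fluorophenyl in place of 3-(trifluoromethyl)phenyl on a nitrogen on an aromatic ring), returning to a 2-halophenyl like compound 1. A rise in the number is therefore expected, a 3.5-fold higher number from compound 2 to compound 3 (0.54 log units; beyond the scatter), since compound 1 gave 43700 nM. Compound 3 is estimated at 30000 nM, within 10000 nM to 90000 nM.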

Compound 3, half-maximal inhibitory concentration: > 64000 nM
Compound 3 gave a limit, no number; the forecaster's own chance of this, stated with the estimate: 10%; middle value at least 2.1-fold (0.32 log units) away from the limit.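

In this assay compound 3 gives only a limit of the assay, not a number: the limit of > 64000 nM in this assay, at which 1 of the 3 values shown sits. The change to 2-fluorophenyl gives an at least 7.4-fold higher number from compound 2 to compound 3 (0.87 log units; beyond the scatter), so a second 2-halophenyl group, after the 2-chlorophenyl of compound 1, also falls well behind 3-(trifluoromethyl)phenyl. Fluoro in place of chloro gives an at least 1.4-fold higher number from compound 1 to compound 3 (0.16 log units; that floor lies within the scatter), so these two halogens cannot be put in order.

As far as these compounds go, it remains open whether the trifluoromethyl group itself or its place on the ring matters. Whether a methoxy group or an amine on this ring would serve equally well is also unknown.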